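Cyclobutyl in place of 2-chlorophenyl at the ring amine

A few compounds are considered here, and "the series" means these few. Any claim that something is new, unique, unknown or untested is made for them only; others in the source may bear on it.

Compound 1, `CCCCCCCN1CCC(C(=O)Nc2cc(Cl)c(N)cc2OC)CC1`, in a functional assay on the whole organism for antagonist activity, with Mus musculus as the target (on this read-out lower numbers stand for an effect already at smaller amounts and higher numbers for an effect only at larger amounts of compound), gives > 10 mg/kg, a limit of the assay.
Compound 2, `COc1cc(N)c(Cl)cc1NC(=O)C1CCN(CC2CC2)CC1`, gives > 10 mg/kg, a limit of the assay.
Compound 3, `COc1cc(N)c(Cl)cc1NC(=O)C1CCN(Cc2ccccc2Cl)CC1`, gives > 4 mg/kg, a limit of the assay.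

Compound 3 stands at the limit of > 4 mg/kg in this assay, at which 1 of the 3 values shown sits. Compounds 1 and 2 stand at the limit of > 10 mg/kg in this assay, at which 2 of the 3 values shown sit. With limits on both sides, the steps a step that the two limits leave unreadable from compound 1 to compound 3 and a step that the two limits leave unreadable from compound 2 to compound 3 cannot be read, and neither can a step that the two limits leave unreadable from compound 1 to compound 2. Compound 4, `COc1cc(N)c(Cl)cc1NC(=O)C1CCN(CC2CCC2)CC1`, differs from compound 3 by cyclobutyl in place of 2-chlorophenyl on a saturated chain carbon bound to an amine nitrogen in a ring. Among the measured compounds shown here, no measured step gives a readable size for this kind of change, so the step that the limit leaves unreadable from compound 3 to compound 4 is estimated as small, with no direction. Compound 4 is expected to give 15 mg/kg, within a range from 4 mg/kg to 60 mg/kg, most likely again only a limit.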

Compound 4, dose for half-maximal effect: > 10 mg/kg
Compound 4 gave a limit, no number (the forecaster's own chance of this, stated with the estimate: 75%); the middle value does not contradict the limit.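

Among the compounds shown here, the result for compound 4 is only a limit of the assay, so no step from compound 1, compound 2 or compound 3 to compound 4 can be read. The compounds shown leave open what dose any of them needs for half-maximal effect.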